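Mirror Image of a Hydroxycyclobutylmethyl Kinase Inhibitor

The source may hold more compounds than are shown below. What is called first, only, known or untested is meant among the compounds shown, and "the series" means these compounds.

Compound 3 `N#Cc1cnc(NCc2cnccc2C(F)(F)F)cc1NC[C@H]1C[C@@H](O)C1` carries a (3-hydroxycyclobutyl)methyl group on a nitrogen on an aromatic ring. Among the compounds with values here, in an assay on isolated protein for inhibition of protein kinase C delta type (Homo sapiens), read by TR-FRET, with a stated time of 2 h (a lower number here means a stronger inhibitor, a higher number a weaker inhibitor), compound 3 gives 4200 nM, the only actual number among the three measured compounds. Compound 1 `N#Cc1cnc(NCc2cnccc2C(F)(F)F)cc1N[C@H]1C[C@@H](O)C1` bears a 3-hydroxycyclobutyl group on that nitrogen, and in this assay compound 1 reaches only the limit > 10000 nM. Compound 2 `N#Cc1cnc(NCc2cnccc2C(F)(F)F)cc1N[C@H]1C[C@H](O)C1` is the mirror image of compound 1, and in this assay compound 2 likewise gives only the limit > 10000 nM. The steps of an at least 2.3-fold lower number from compound 1 to compound 3 (0.37 log units; beyond the scatter) and an at least 2.3-fold lower number from compound 2 to compound 3 (0.37 log units; beyond the scatter) thus mark the switch to the (3-hydroxycyclobutyl)methyl group as at least modest gains, whereas the step that the two limits leave unreadable from compound 1 to compound 2 is unreadable because of the limit of > 10000 nM in this assay, at which 2 of the 3 values shown sit.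

Compound 4 `N#Cc1cnc(NCc2cnccc2C(F)(F)F)cc1NC[C@H]1C[C@H](O)C1` differs from compound 3 only in configuration: the two compounds have the same atoms and bonds and differ only in configuration as drawn: 2 of 2 stereo elements differ (all stereocentres are inverted: mirror images); a stereocentre at a saturated ring carbon is drawn s in compound 3 and r in compound 4; a stereocentre at a saturated ring carbon is drawn s in compound 3 and r in compound 4. Within the data shown here, the single measured step of the same kind gives no direction, because of the fact that compounds 1 and 2 differ only in the configuration as drawn combined with the limit of > 10000 nM in this assay, at which 2 of the 3 values shown sit, it shows neither gain nor loss. Among the measured compounds shown here, no other step bears on a mirror-image swap. The expected step of a 1.2-fold higher number from compound 3 to compound 4 (0.08 log units; within the scatter) is therefore centred on no change, with wide uncertainty in both directions. For compound 4 the estimate is 5000 nM, expected to lie between 1200 nM and 20000 nM.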

Compound 4, half-maximal inhibitory concentration: > 10000 nM
Compound 4 was reported as a limit; the forecaster's own chance of this, stated with the estimate: 35%; middle value at least 2.0-fold (0.30 log units) from the limit.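

In this assay a mirror-image swap now has a readable direction, with an at least 2.3-fold higher number from compound 3 to compound 4 (0.37 log units; beyond the scatter), so on the (3-hydroxycyclobutyl)methyl group the configuration as drawn does matter, and the difference in this pair rests on configuration alone: the fact that compounds 3 and 4 differ only in the configuration as drawn. The gain seen earlier on going from the 3-hydroxycyclobutyl group to the (3-hydroxycyclobutyl)methyl group therefore belongs to the configuration drawn in compound 3, and the group as such does not secure it, since compound 4 carries the same group. The steps from compound 1 to compound 4 and from compound 2 to compound 4 cannot be read because both ends of each are limits rather than numbers: the limit of > 10000 nM in this assay, at which 3 of the 4 values shown sit.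

Within the data shown here, with compound 3 the only compound giving a number, it stays open how large the loss in compound 4 really is, and whether the hydroxyl group takes any part in the difference between the two mirror images. A (3-aminocyclobutyl)methyl group, with an amine in place of the hydroxyl, or a plain cyclobutylmethyl group on the same nitrogen would bear on that question.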